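The source may hold more compounds than are shown below. What is called first, only, known or untested is meant among the compounds shown, and "the series" means these compounds.

Measured in an ADME assay on HS27 cells (Homo sapiens) for antiproliferative activity, read by sulforhodamine B assay, with a stated time of 48 h (a lower number here means a stronger inhibitor, a higher number a weaker inhibitor), each value a limit of the assay and not a number:

- compound 1 `O=C(O)c1cc2cc(-c3ccc(C(F)(F)F)cc3)ccc2n1O`: > 100000 nM
- compound 2 `COc1ccc(-c2ccc3c(c2)cc(C(=O)O)n3O)cc1`: > 100000 nM
- compound 3 `O=C(O)c1cc2ccc(-c3ccc(Cl)cc3)cc2n1O`: > 100000 nM

Not yet measured: compound 4 `O=C(O)c1cc2ccc(-c3ccc(C(F)(F)F)cc3)cc2n1O`.

Compound 3 stands at a limit, > 100000 nM, so the starting point for this step is not a number. It shares that position with the other two measured compounds: the limit of > 100000 nM in this assay, at which 3 of the 3 values shown sit.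

The change to compound 4 is trifluoromethyl in place of chloro on an aromatic carbon, para to a large group.

For the measured compounds named here, only one measured step bears on it, a step that the two limits leave unreadable from compound 1 to compound 2. That step also exchanges a group on an aromatic carbon, here methoxy in place of trifluoromethyl, but it has no readable size to carry over. Going by the values given here, no compound yet gives a number in this assay, and no step beyond the scatter is expected in either direction. Compound 4 is therefore expected to report the same limit as compound 3, and a true number, if one were returned, should lie near that limit.

The estimated step is a step that the limit leaves unreadable from compound 3 to compound 4.

The expected value for compound 4 is 120000 nM, within an estimated range of 50000 nM to 300000 nM.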

Compound 4, half-maximal inhibitory concentration: 68000 nM
Beside the measured number, compound 4's estimate is 1.8-fold (0.25 log units) above it; the measured number falls inside the stated range.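

this assay now has one readable number: compound 4 gives 68000 nM. The other compounds shown remain at a limit: the limit of > 100000 nM in this assay, at which 3 of the 4 values shown sit.

For the compounds shown here, with trifluoromethyl in place of chloro on an aromatic carbon, para to a large group, the series shows an at least 1.4-fold lower number from compound 3 to compound 4 (0.16 log units; that floor lies within the scatter), the only step so far with a readable direction. Going by these compounds, compound 3 is a limit, so this figure is only a floor on the step, the true size remains unknown, and the step from compound 1 to compound 2 cannot be read.

On these data alone, whether another group at this position, such as an amine, a nitrile or a longer chain, would give a clearly lower number remains open. Also open, as far as these compounds go, is whether any number well below that of compound 4 can be reached on this core with an amide in place of the carboxylic acid.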